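This account rests on a few compounds, and the source may have more. Where it says the series, first, only, none or still open, it means among the compounds named here.

Compound 1 `COc1cccc(S(=O)(=O)/C=C/c2ccccn2)c1` carries a methoxy group on one aromatic ring, and a sulfonyl-linked alkene joins it to a ring with one nitrogen. In an assay on U2OS cells for activation of nuclear factor erythroid 2-related factor 2 (Homo sapiens), read by chemiluminescence, with a stated time of 6 h (a lower number here means that less compound is needed, a higher number that more compound is needed for the effect), compound 1 gives 2170 nM. Compound 2 `COc1cccc(S(=O)(=O)/C=C/c2ncccc2F)c1` differs from it by a single change, (fluoro in place of hydrogen on an aromatic carbon), and in this assay compound 2 gives 444 nM. That change made a 4.9-fold lower number from compound 1 to compound 2 (0.69 log units; beyond the scatter).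

Compound 3 `COc1ccc(S(=O)(=O)/C=C/c2cccnc2)cc1` has the same atoms as compound 1 joined differently; the difference between the two cores is not broken down here. In this assay compound 3 reached only the limit (the limit of > 10000 nM in this assay, at which 1 of the 3 values shown sits), so its value of > 10000 nM is a limit of the assay and not a number.

Compound 4 `COc1ccc(S(=O)(=O)/C=C/c2ccc(F)nc2)cc1` is not yet measured. It differs from compound 3 by fluoro in place of hydrogen on an aromatic carbon, the same kind of change as from compound 1 to compound 2, though the place is not the same: there the fluoro stood ortho to a large group and two atoms from the ring nitrogen. A step of about the earlier size is expected, giving an at least 1.4-fold lower number from compound 3 to compound 4 (0.15 log units; that floor lies within the scatter), and that rests on the measured step of a 4.9-fold lower number from compound 1 to compound 2 (0.69 log units; beyond the scatter). Compound 4 is therefore expected to give roughly 7000 nM in this assay, between 2000 nM and 25000 nM.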

Compound 4, half-maximal effective concentration: 6850 nM
For compound 4 the middle estimate is 1.0-fold (0.01 log units) above the measured one; measured number inside the range.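

In this assay compound 3 gives > 10000 nM, which is a limit of the assay and not a number. Fluoro in place of hydrogen on an aromatic carbon gives an at least 1.4-fold lower number from compound 3 to compound 4 (0.16 log units; that floor lies within the scatter), which points the same way as the step on the first core, but a floor inside the usual scatter cannot by itself show a real gain on this core. The change can therefore be said to carry over in direction at most, not in size, and the fluoro also stands in a different place on each core: the same change on two cores in this assay, a 4.9-fold lower number (0.69 log units; beyond the scatter) from compound 1 to compound 2 and an at least 1.4-fold lower number (0.16 log units; that floor lies within the scatter) from compound 3 to compound 4; the limit leaves it open whether they differ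

In the compounds shown, fluoro enters only the ring with one nitrogen, so its effect on the methoxy-bearing ring remains open. Also open, on these data alone, is whether chloro, a methyl group or a nitrile in the place of the fluoro would move the number as fluoro does, and what an amine or a longer chain in place of the methoxy group would do.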